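Phenyl in Place of Benzyl on the Urea Nitrogen

The source may hold more compounds than are shown below. What is called first, only, known or untested is meant among the compounds shown, and "the series" means these compounds.

Compound 1 `COc1ccc(-c2cnc3nc(N)nc(N4CCN(C(=O)NCc5ccccc5)CC4)c3n2)cc1OC` is the reference point of this set. In a functional assay on cells (T-cell, Homo sapiens) for inhibition (a lower number here means a stronger inhibitor, a higher number a weaker inhibitor), compound 1 gives 18 nM, the lowest of the two numbers recorded. Compound 2 `COc1ccc(-c2cnc3nc(N)nc(NCc4ccccc4)c3n2)cc1OC`, which carries a benzylamino group directly on the shared core instead of the piperazine urea, is a far weaker inhibitor: in this assay compound 2 gives 13000 nM. Compound 3 `CCOc1nc(N)nc2ncc(-c3ccc(F)c(F)c3)nc12` was also tested, and for it the assay returned only a limit, not a number: in this assay compound 3 gives > 10000 nM. This is the limit of > 10000 nM in this assay, at which 1 of the 3 values shown sits.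

The step of interest leads from compound 1 to compound 4 `COc1ccc(-c2cnc3nc(N)nc(N4CCN(C(=O)Nc5ccccc5)CC4)c3n2)cc1OC`. The two differ in one place only: phenyl in place of benzyl on an amide-type nitrogen. The urea and the piperazine are kept; the aromatic ring simply moves one bond closer to the amide-type nitrogen.

Within the data shown here, no measured pair in this set differs by exactly this change, so the size of the step rests on judgement rather than on a precedent. A change this small, at the outer end of the molecule, is expected to leave the number close to that of compound 1, with the expected step of a 1.4-fold higher number from compound 1 to compound 4 (0.14 log units; within the scatter) lying within the usual scatter. Compound 4 is therefore expected to give about 25 nM, with a likely range from 6 nM to 100 nM.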

Compound 4, half-maximal inhibitory concentration: 3.4 nM
Beside the measured number, compound 4's estimate is 7.4-fold (0.87 log units) above it, outside the stated range (below it).
By their numbers in this assay, from the lowest: compound 4; then compound 1; then compound 2.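

In this assay, phenyl in place of benzyl on the amide-type nitrogen gives a 5.3-fold lower number from compound 1 to compound 4 (0.72 log units; beyond the scatter), so the outer end of the molecule responds to a change as small as this one. Among these compounds, the earlier compounds could not show this, as none of them formed a pair differing in one place; this is the first such step in the set, and it shows that the benzyl group is not needed for a low number in this assay. The data shown offer no measured property that accounts for this step, so it stands as an observation about these two compounds alone.

A single step cannot tell whether the aromatic ring itself matters on this nitrogen, or whether a cyclohexyl ring, a methyl group or a longer chain such as phenethyl would serve as well. Also open, from the compounds shown here alone, is whether a fluorine or a methoxy group on the phenyl ring would shift the number further, and whether a plain amide could replace the urea while the phenyl stays.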